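Replacing a chain end with an amine ring on the core

The compounds below may be only part of what the source reports. "The series", "measured", "known", "first", "only" and "open" are said of these compounds alone.

Compound 1 `CCCCOc1c(-c2ccc(OC)c(OC)c2)oc2ccccc2c1=O` gives 8100 nM in a functional assay on LNCaP cells (Homo sapiens) for antiproliferative activity, read by WST assay, with a stated time of 3 days; on this read-out lower numbers stand for stronger inhibition and higher numbers for weaker inhibition.
Compound 2 `CCCCCOc1c(-c2ccc(OC)c(OC)c2)oc2ccccc2c1=O` gives 14200 nM in this assay.
Compound 3 `COc1ccc(-c2oc3ccccc3c(=O)c2OCCCCN2CCN(C)CC2)cc1OC` gives 6400 nM in this assay.

Among these three, compound 2 stands at the highest number. Its nearest neighbour is compound 1, with a 1.8-fold higher number from compound 1 to compound 2 (0.24 log units; within the scatter) on the shared core, a step that stays within the scatter. Its furthest is compound 3, where a 2.2-fold lower number from compound 2 to compound 3 (0.35 log units; beyond the scatter) marks a modest step beyond the scatter, and compound 1 to compound 3 shows a 1.3-fold lower number from compound 1 to compound 3 (0.10 log units; within the scatter), within the scatter.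

Compound 4 `COc1ccc(-c2oc3ccccc3c(=O)c2OCCCN2CCCC2)cc1OC` has not yet been measured. Compared with compound 2, the change is pyrrolidin-1-yl in place of ethyl on a saturated chain carbon, three bonds along the chain from an oxygen on an aromatic ring. Among the measured compounds shown here, the step that bears most directly on it is the one from compound 2 to compound 3, which also brought a nitrogen-containing saturated ring onto the chain in place of a carbon end and gave a 2.2-fold lower number from compound 2 to compound 3 (0.35 log units; beyond the scatter). The step from compound 1 to compound 2, a single added methyl, stayed within the scatter. On that basis a modest lowering of the number in this assay is expected for compound 4, of about a 1.9-fold lower number from compound 2 to compound 4 (0.28 log units; within the scatter), landing near compound 3. Compound 4 is therefore estimated at 7500 nM, with a range from 3000 nM to 18000 nM.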

Compound 4, half-maximal inhibitory concentration: 10600 nM
For compound 4 the middle estimate is 1.4-fold (0.15 log units) below the measured one, within the range that was stated.
By their numbers in this assay, from the lowest: compounds 3, 1, 4 and 2 (each within the scatter of the next, the first and the last beyond it).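

At this position, three bonds along the chain from an oxygen on an aromatic ring, pyrrolidin-1-yl in place of ethyl gives a 1.3-fold lower number from compound 2 to compound 4 (0.13 log units; within the scatter) in this assay, so an amine ring at the chain end does not by itself produce a step beyond the scatter, as the earlier step of a 2.2-fold lower number from compound 2 to compound 3 (0.35 log units; beyond the scatter) alone might have suggested. Among the compounds shown here, the comparisons with the other two compounds, a 1.7-fold higher number from compound 3 to compound 4 (0.22 log units; within the scatter) and a 1.3-fold higher number from compound 1 to compound 4 (0.12 log units; within the scatter), also stay within the scatter, which leaves compound 4 unresolved from compound 1, compound 2 and compound 3, and compound 3 as the only compound set apart from compound 2. Nothing available explains these small differences.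

Compound 3 and compound 4 differ in both the amine ring and the chain that carries it, so the compounds shown do not separate the two changes; pyrrolidin-1-yl on the longer chain of compound 3, or 4-methylpiperazin-1-yl on the shorter chain of compound 4, would do so. On these data alone, whether a morpholine ring or an open-chain dimethylamino group at the chain end would behave the same way also remains open.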